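From Compound 2 to Compound 3: An Oxetane Exchange

A few compounds are considered here, and "the series" means these few. Any claim that something is new, unique, unknown or untested is made for them only; others in the source may bear on it.

Of the compounds shown here, two have so far been measured in a physicochemical assay for solubility, read by chemiluminescence, measured as kinetic solubility; a higher number here means a more soluble compound, a lower number a less soluble compound. Compound 1 `CC(=O)NCc1cccc(Cn2nc(NS(=O)(=O)c3ccc(Cl)s3)c3c(C#N)cccc32)c1` returned only a limit of the assay, >= 155 ug/mL, and not a number. Among the compounds with values here, compound 2 `COc1cccc2c1c(NS(=O)(=O)c1ccc(Cl)s1)nn2Cc1cccc(CNC(=O)C2CCO2)c1` gave 124 ug/mL, the only exact number available, so it stands without a measured step to set it against.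

Compound 3 `COc1cccc2c1c(NS(=O)(=O)c1ccc(Cl)s1)nn2Cc1cccc(CNC2COC2)c1` keeps the core of compound 2 and differs from it in one place, with oxetan-3-yl in place of (oxetan-2-yl)carbonyl on an amine nitrogen. Within the data shown here, no measured step shows what this exchange does in this assay, so no step beyond the usual scatter is expected, in either direction. The expectation stays close to compound 2 at 124 ug/mL. The estimated step is a 1.0-fold lower number from compound 2 to compound 3 (0.01 log units; within the scatter). Compound 3 is expected at 120 ug/mL, with an estimated range of 60 ug/mL to 160 ug/mL.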

Compound 3, solubility: 122 ug/mL
Compound 3: the middle estimate sits 1.0-fold (0.01 log units) below what was measured, within the range that was stated.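

Within the data shown here, the exchange on the amine nitrogen is the first step in this set between compounds that differ in one place, and in this assay it gives a 1.0-fold lower number from compound 2 to compound 3 (0.01 log units; within the scatter), the only such step available so far. It takes away the carbonyl and brings the group on that nitrogen from 6 heavy atoms to 4, yet the read-out stays within the scatter at this position. Compound 1 remains a limit and not a number: the limit of >= 155 ug/mL in this assay, at which 1 of the 3 values shown sits.

Still open, as far as these compounds go, is how a group of another kind on this amine nitrogen, such as a carboxylic acid or a longer chain, would read. The compounds shown also do not tell whether the same exchange would give a similar step on another core, such as that of compound 1.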